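The source may report more compounds than this note shows. Statements on the series, on what has been measured and on what is new or still open speak of the compounds shown alone.

Measured compounds:
compound 1, `CCOC(=O)c1c(CSc2nccn2C)nc2cc(OC)c(OC)cc2c1-c1ccc(OC)c(OC)c1`, in a functional assay on the whole organism for inhibition, with Rattus norvegicus as the target, at a dose of 50 mg/kg by the oral route (a higher number here means more inhibition at the dose given (going by the name of the read-out), a lower number less inhibition), compound 1 gives 60%.
compound 2, `CCOC(=O)c1c(CSc2nncn2C)nc2cc(OC)c(OC)cc2c1-c1ccc(OC)c(OC)c1`, in this assay compound 2 gives 66%.
compound 3, `CCOC(=O)c1c(CSc2nccn2C)nc2cc(OC)c(OC)cc2c1-c1ccc(OC)cc1`, in this assay compound 3 gives 64%.

All three numbers sit close together. Among the compounds with values here, the step of a number 6 percentage points higher from compound 1 to compound 2 (within the scatter) and the step of a number 4 percentage points higher from compound 1 to compound 3 (within the scatter) both fall within the scatter of repeated measurements, so no compound is set apart from the others. Compound 3 holds the second highest of the three numbers, with compound 2 nearest and compound 1 furthest, and neither gap counts as a real difference.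

The next compound, compound 4, `CCOC(=O)c1c(CSc2nccn2C)nc2cc(OC)c(OC)cc2c1-c1ccc(C)cc1`, has not been measured. It differs from compound 3 in one place: methyl in place of methoxy on an aromatic carbon.

Within the data shown here, no measured step swaps methyl for methoxy. The nearest comparison is the step from compound 1 to compound 3, where methoxy left an aromatic carbon and a hydrogen took its place, with a result within the scatter. The series so far has shown no change beyond the scatter for any of its steps. Compound 4 is therefore expected to give about 62% in this assay, in a range from 48% to 76%. This estimate means a step of a number 2 percentage points lower from compound 3 to compound 4 (within the scatter), which is expected to stay within the scatter.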

Compound 4, a percentage reported as inhibition, in the whole organism at one dose (the size of the read-out at that dose, not a potency): 67%
Compound 4: middle estimate off by 5 percentage points, on the low side; measured number inside the range.
By their numbers in this assay, from the lowest: compounds 1, 3, 2 and 4 (each within the scatter of the next).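

In this assay, the position para to a large group now has a direct reading: the step from 4-methoxyphenyl to 4-methylphenyl, with one hydrogen-bond acceptor leaving, is a number (a number 3 percentage points higher from compound 3 to compound 4 (within the scatter)). Within the data shown here, the earlier step on this aryl group changed a different carbon and left this methoxy in place, so this is the first sign that this methoxy can be exchanged without a change beyond the scatter. Among these compounds, the wider change from 3,4-dimethoxyphenyl to 4-methylphenyl, which removes both methoxy groups, also stays small (a number 7 percentage points higher from compound 1 to compound 4 (within the scatter)), so the series so far shows no need for either methoxy in this read-out at this single dose. No evidence bearing on why these numbers stay so close accompanies the result.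

The compounds shown leave open whether any group on this carbon moves the number beyond the scatter, for instance an amine, a carboxylic acid or a longer chain such as butyl. They also leave open how plain phenyl behaves, and whether the flat picture would hold at a lower dose, where a single-dose percentage might separate these compounds.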